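Taking a methyl group off compound 2

A few compounds are considered here, and "the series" means these few. Any claim that something is new, unique, unknown or untested is made for them only; others in the source may bear on it.

Of the compounds shown here, two sharing one core have been measured in a functional assay on MCF7 cells (Homo sapiens) for cytotoxicity; a lower number here means a stronger inhibitor, a higher number a weaker inhibitor. In that test compound 1 (`C=C/C=C\[C@H](C)[C@H](OC(N)=O)[C@@H](C)[C@H](O)[C@@H](C)C/C(C)=C\[C@H](C)[C@@H](O)[C@@H](C)/C=C\CCc1ccc(Oc2ccccc2)cc1`) gives 10000 nM, and compound 2 (`C=C/C=C\[C@H](C)[C@H](OC(N)=O)[C@@H](C)[C@H](O)[C@@H](C)C/C(C)=C\[C@H](C)[C@@H](O)[C@@H](C)/C=C\CCc1ccc(C)c(F)c1`) gives 4000 nM. Compound 2 therefore holds the lower of the two numbers, by a gap beyond the usual scatter. Compound 3 (`C=C/C=C\[C@H](C)[C@H](OC(N)=O)[C@@H](C)[C@H](O)[C@@H](C)C/C(C)=C\[C@H](C)[C@@H](O)[C@@H](C)/C=C\CCc1cccc(F)c1`) departs from compound 2 by a single change: hydrogen in place of methyl on an aromatic carbon, ortho to a fluoro group and para to a large group. Among the measured compounds shown here, no measured pair isolates this change, so any expectation rests on compound 2 at 4000 nM alone. A small move towards a higher number in this assay is expected, possibly none beyond the scatter. The expected step is a 1.3-fold higher number from compound 2 to compound 3 (0.10 log units; within the scatter). For compound 3 the estimated value is 5000 nM, with an expected range from 2000 nM to 12000 nM.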

Compound 3, half-maximal inhibitory concentration: 500 nM
Estimate against measurement, compound 3: 10-fold (1.00 log units) above; measured number below the stated range.
By their numbers in this assay, from the lowest: compound 3; then compound 2; then compound 1.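

In this assay, among the compounds shown here, taking the methyl group off the 3-fluoro-4-methylphenyl end gives an 8.0-fold lower number from compound 2 to compound 3 (0.90 log units; beyond the scatter), and this is the only measured pair that isolates a single change. It shows that the aromatic carbon ortho to a fluoro group and para to a large group is sensitive to substitution, as even this one-carbon difference moves the number beyond the scatter, with hydrogen giving the lower number. Nothing at hand accounts for the size of this step.

The compounds shown leave open whether a group other than methyl at this carbon, such as a chlorine, a methoxy group or a hydroxyl group, would also raise the number. They also leave open what the fluoro group contributes, which a plain phenyl end would test.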